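The source may report more compounds than this note shows. Statements on the series, on what has been measured and on what is new or still open speak of the compounds shown alone.

Measured compounds in the series:

Compound 1, `NC1=NC2(CCCCC2)N(c2ccccc2)C(N)=N1`. In an assay for inhibition of Dihydrofolate reductase (Bos taurus), using NADPH (on this read-out higher numbers stand for weaker inhibition and lower numbers for stronger inhibition), compound 1 gives > 100000 nM, which is a limit of the assay and not a number.
Compound 2, `NC1=NC2(CCCCC2)N(c2ccccc2Cl)C(N)=N1`. In this assay compound 2 gives > 100000 nM, again a limit.
Compound 3, `NC1=NC2(CCCCC2)N(c2ccc(Cl)cc2)C(N)=N1`. In this assay compound 3 gives > 100000 nM, also a limit.

Compound 3 therefore stands only at a limit in this assay, as do the other two measured compounds; all three sit at the limit of > 100000 nM in this assay, at which 3 of the 3 values shown sit. The steps a step that the two limits leave unreadable from compound 1 to compound 2 and a step that the two limits leave unreadable from compound 1 to compound 3 cannot be sized, since both ends are limits.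

Compound 4 is `Cc1ccc(N2C(N)=NC(N)=NC23CCCCC3)cc1`. It differs from compound 3 by methyl in place of chloro on an aromatic carbon. The measured steps that bear on it, from compound 1 to compounds 2 and 3, change the same aromatic ring and neither step moved a compound off the limit. Among the measured compounds shown here, no measured step gives a readable size, so no direction beyond the scatter can be expected for the step from compound 3 to compound 4 in this assay. The estimate is that compound 4 stays at the limit, with an expected step that the limit leaves unreadable from compound 3 to compound 4. Compound 4 is accordingly estimated at 150000 nM, with a range from 40000 nM to 600000 nM.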

Compound 4, half-maximal inhibitory concentration: > 100000 nM
Compound 4 gave a limit, no number; the forecaster's own chance of this, stated with the estimate: 85%; the middle value does not contradict the limit.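

In this assay the steps to compound 4 from compound 3 and from compound 1 cannot be read, as each end is a limit and not a number: the limit of > 100000 nM in this assay, at which 4 of the 4 values shown sit. The compounds shown leave open whether any change to the shared core gives a readable value in this assay.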